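Chloro on the five-membered ring of compound 1

A few compounds are considered here, and "the series" means these few. Any claim that something is new, unique, unknown or untested is made for them only; others in the source may bear on it.

The shared core is that of compound 1 `C[C@H](Nc1nccc(Nc2cc(C3CC3)[nH]n2)n1)c1ccc2[nH]ccc2n1`, which in an assay for inhibition of serine/threonine-protein kinase PAK 1 (Homo sapiens), read by FRET and Z'-LYTE, with stated times of 10 min and 60 min (a lower number here means a stronger inhibitor, a higher number a weaker inhibitor), gives 32 nM. Compound 2 `CC[C@H](Nc1nccc(Nc2cc(C3CC3)[nH]n2)n1)c1ccc2[nH]ccc2n1` carries a methyl in place of hydrogen on a saturated chain carbon, two bonds along the chain from an aromatic carbon and a nitrogen on an aromatic ring; in this assay compound 2 gives 23 nM. The step of a 1.4-fold lower number from compound 1 to compound 2 (0.14 log units; within the scatter) is the only one measured. Of the two numbers compound 1 holds the higher, yet the gap to compound 2 lies within the scatter, so no order follows from it.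

Compound 3 `C[C@H](Nc1nccc(Nc2cc(C3CC3)[nH]n2)n1)c1ccc2[nH]cc(Cl)c2n1` differs from compound 1 by chloro in place of hydrogen on an aromatic carbon. For the measured compounds named here, no measured step concerns this ring or a chloro group; the one known step sits on the chain and is within the scatter. The number for compound 3 is therefore expected to stay near that of compound 1, and the step of a 1.1-fold lower number from compound 1 to compound 3 (0.06 log units; within the scatter) is estimated to fall within the scatter. For compound 3 in this assay the estimate is 28 nM, with a range from 9 nM to 90 nM.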

Compound 3, inhibition constant: 6 nM
Compound 3: middle estimate off by 4.7-fold (0.67 log units), on the high side; measured number below the stated range.
By their numbers in this assay, from the lowest: compound 3; then compounds 2 and 1 (each within the scatter of the next).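

Chloro in place of hydrogen on an aromatic carbon of the five-membered aromatic ring gives a 5.3-fold lower number from compound 1 to compound 3 (0.73 log units; beyond the scatter) in this assay and is the first listed step beyond the scatter. The earlier chain step, a 1.4-fold lower number from compound 1 to compound 2 (0.14 log units; within the scatter) and within the scatter, showed no such separation, so this ring carbon, two ring bonds from the ring nitrogen, is a place where a single chlorine atom moves the number measurably. The compounds shown offer no evidence on the reason for this step.

On these data alone, whether bromo, methyl or a nitrile on the same carbon would give a step of similar size stays open, so the result cannot yet be read as specific to chloro. Also open, as far as these compounds go, is whether the chloro step carries over to the core of compound 2.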